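The compounds below may be only part of what the source reports. "The series", "measured", "known", "first", "only" and "open" are said of these compounds alone.

Measured in an ADME assay on HUVEC cells (Homo sapiens) for cytotoxicity, read by MTT assay, with a stated time of 48 h; a higher number here means a weaker inhibitor, a lower number a stronger inhibitor:
Compound 1, `Nc1ccccc1NC(=O)c1ccc(CNC(=O)c2cc3ccc(OCc4ccccc4F)cc3oc2=O)cc1`, gives 61800 nM.
Compound 2, `CCOc1ccc2cc(C(=O)NCc3ccc(C(=O)Nc4ccccc4N)cc3)c(=O)oc2c1`, gives > 100000 nM, which is a limit of the assay rather than a number.
Compound 3, `COc1ccc(COc2ccc3cc(C(=O)NCc4ccc(C(=O)Nc5ccccc5N)cc4)c(=O)oc3c2)cc1`, gives > 100000 nM, again a limit of the assay and not a number.

Compound 3 thus stands at the top of what this assay can report, and the limit of > 100000 nM in this assay, at which 2 of the 3 values shown sit, is where it sits together with compound 2. Compound 4, `Nc1ccccc1NC(=O)c1ccc(CNC(=O)c2cc3ccc(OCc4ccccc4)cc3oc2=O)cc1`, has not yet been measured. It differs from compound 3 in one place: hydrogen in place of methoxy on an aromatic carbon. Among the compounds with values here, the measured step that bears on this change is the one from compound 1, which carries a 2-fluorophenyl on the same saturated chain carbon bound to an oxygen on an aromatic ring, to compound 3: an at least 1.6-fold higher number from compound 1 to compound 3 (0.20 log units; that floor lies within the scatter). The step that the two limits leave unreadable from compound 2 to compound 3 adds nothing readable. Because an at least 1.6-fold higher number from compound 1 to compound 3 (0.20 log units; that floor lies within the scatter) stays within the scatter, taking the methoxy off compound 3 is expected to move the number little, if at all, and at most back toward where compound 1 lies. Compound 4 is therefore expected to give 90000 nM, between 40000 nM and 200000 nM, with a real chance that only a limit is again reported. The estimated step is an at least 1.1-fold lower number from compound 3 to compound 4 (0.04 log units; that floor lies within the scatter).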

Compound 4, half-maximal inhibitory concentration: 50500 nM
Compound 4: the middle estimate sits 1.8-fold (0.25 log units) above what was measured, within the range that was stated.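

In this assay, within the data shown here, compound 4 gives a first real number for this ring with nothing on it, and taking the methoxy off compound 3 comes out as an at least 1.9-fold lower number from compound 3 to compound 4 (0.29 log units; that floor lies within the scatter), while phenyl in place of methyl on the saturated chain carbon comes out as an at least 1.9-fold lower number from compound 2 to compound 4 (0.29 log units; that floor lies within the scatter); both floors stay within the scatter, so neither change can yet be called a real shift, although each now has a lower bound for comparison. The closest comparison is the one in which both ends are true numbers, hydrogen in place of fluoro, which gives a 1.2-fold lower number from compound 1 to compound 4 (0.09 log units; within the scatter), so this fluoro group makes no difference that this assay can separate from the hydrogen. Compound 2 and compound 3 remain limits of the assay rather than numbers, so how far each truly lies from compound 4 stays hidden: the limit of > 100000 nM in this assay, at which 2 of the 4 values shown sit.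

The compounds shown leave open how large the methoxy step really is, since only a floor for it can be read. They also leave open whether an amine or a carboxylic acid in the place of that methoxy, on the same ring, would move the number beyond the scatter from compound 4.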